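The source may hold more compounds than are shown below. What is called first, only, known or untested is meant among the compounds shown, and "the series" means these compounds.

Measured so far in an assay on isolated protein for inhibition of serine/threonine-protein kinase TBK1 (Homo sapiens); a lower number here means a stronger inhibitor, a higher number a weaker inhibitor:
Compound 1 `CC(C)n1cc(Nc2ncc(C3CC3)c(NCCCNC(=O)C3CCC3)n2)cn1` gives 4 nM.
Compound 2 `O=C(NCCCNc1nc(Nc2cccnc2)ncc1C1CC1)C1CCC1` gives 13 nM.
Compound 3 `CC(=O)N1CCC(C(=O)NCCCNc2nc(Nc3cccc(F)c3)ncc2Br)CC1` gives 430 nM.

Compound 2 stands second highest of these three numbers in this assay. Its nearest neighbour is compound 1, and the step from compound 1 to compound 2 is a 3.3-fold higher number from compound 1 to compound 2 (0.51 log units; beyond the scatter). Going by the values given here, compound 3 is the furthest; no single-point step links it to compound 2, and the two values show only that compound 3 sits well above compound 2.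

Compound 4 `O=C(NCCCNc1nc(Nc2cncnc2)ncc1C1CC1)C1CCC1` is compound 2 with pyrimidin-5-yl in place of pyridin-3-yl on a nitrogen on an aromatic ring. Among the compounds with values here, only one measured step bears on this position: the step from compound 1 to compound 2, a 3.3-fold higher number from compound 1 to compound 2 (0.51 log units; beyond the scatter), where a different group was exchanged at the same nitrogen. That step was modest, and the present change is smaller in kind, the ring keeping its size and gaining one hetero atom. Within the data shown here, compound 3 carries yet another group at this nitrogen but differs elsewhere as well, so it gives no step to lean on.

In this assay compound 4 is therefore expected to give a number close to that of compound 2, with at most a small shift toward a higher number, the step from compound 2 to compound 4 being estimated as a 1.5-fold higher number from compound 2 to compound 4 (0.19 log units; within the scatter). The estimate for compound 4 is 20 nM, with a range from 8 nM to 60 nM.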

Compound 4, half-maximal inhibitory concentration: 3200 nM
Estimate against measurement, compound 4: 160-fold (2.20 log units) below; the measured number lies above the stated range.
By their numbers in this assay, from the lowest: compound 1; then compound 2; then compound 3; then compound 4.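

In this assay, going by these compounds alone, this nitrogen proves far more sensitive to the choice of aromatic ring than the earlier compounds showed: pyrimidin-5-yl in place of pyridin-3-yl keeps the six-membered aromatic ring and its heavy-atom count, exchanges one carbon for a nitrogen, and still gives a 250-fold higher number from compound 2 to compound 4 (2.39 log units; beyond the scatter), much larger than the earlier 3.3-fold higher number from compound 1 to compound 2 (0.51 log units; beyond the scatter). Across the three groups compared on this shared core, the spread therefore reaches an 800-fold higher number from compound 1 to compound 4 (2.90 log units; beyond the scatter), and the size of the ring or the count of its heavy atoms alone does not account for the order of the values. No measured evidence bears on the reason for this large step.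

The compounds shown leave open whether the sharp loss follows from the second ring nitrogen as such or from where it sits, which a pyridin-4-yl, pyrazin-2-yl or plain phenyl group on the same nitrogen would help to separate. They also leave open whether the exchange of pyridin-3-yl for pyrimidin-5-yl has a similar size when bromine replaces the cyclopropyl group on the core.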